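The compounds below may be only part of what the source reports. "The series", "measured", "known", "first", "only" and "open" are said of these compounds alone.

In a functional assay on KB cells (Homo sapiens) for inhibition, read by MTT assay, with a stated time of 24 h, tested at 1 ug/mL (on this read-out lower numbers stand for less inhibition of growth and higher numbers for more inhibition of growth at the one concentration tested), compound 1 (`O=C(CCCCC1CCSS1)Nc1ccccn1`) reads "not active" (no number reported) with no number reported. Compound 2 (`O=C(CCCCC1CCSS1)Nc1ccc(Cl)cn1`) gives 0.76% as the only number shown so far, so there is no second number to rank it against. Compound 3 (`O=C(CCCCC(S)CCS)Nc1ccc(Cl)cn1`) differs from compound 2 in one place (a group of 5 heavy atoms (3 carbon, 2 sulfur; no ring) in place of a group of 5 heavy atoms (3 carbon, 2 sulfur; one five-membered non-aromatic ring with 2 hetero atoms), on a saturated chain carbon, four bonds along the chain from a carbonyl carbon): the five-membered non-aromatic ring gives way to 1,3-disulfanylpropyl, on a saturated chain carbon, four bonds along the chain from a carbonyl carbon. Among the compounds with values here, no measured pair shows what such a change does. Only a small rise in inhibition of growth is therefore expected, and possibly nothing beyond the usual scatter. The estimate is a step of a number 3.2 percentage points higher from compound 2 to compound 3 (within the scatter) and this expected step stays within that scatter. The estimate for compound 3 is 4% with an expected range of 0% to 15% in this assay and a report without a number remains possible.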

Compound 3, percent growth inhibition at one concentration: "not active" (no number reported)
No number was reported for compound 3; no gap can be computed for the estimate.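

In this assay, within the data shown here, compound 3 gives "not active" (no number reported) and so no step from compound 2 to compound 3 can be read. No supporting data bear on this result. The compounds shown leave open whether 1,3-disulfanylpropyl in place of the five-membered non-aromatic ring changes inhibition of growth at all.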